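Swapping chloro for bromo in a cytotoxic compound

The source may report more compounds than this note shows. Statements on the series, on what has been measured and on what is new or still open speak of the compounds shown alone.

Measured in a functional assay on 518A2 cells (Homo sapiens) for cytotoxicity, read by MTT assay, with a stated time of 72 h; a lower number here means a stronger inhibitor, a higher number a weaker inhibitor:
- Compound 1 `COc1ccc(-c2c(-c3cc(Cl)c(OC)c(OC)c3)ncn2C)cc1F`: 400 nM
- Compound 2 `COc1cc(-c2ncn(C)c2-c2ccc(N(C)C)cc2)cc(Cl)c1OC`: 2300 nM

For the measured compounds named here, only two measurements are available so far. Compound 2, at 2300 nM, has the higher number and is therefore the weaker inhibitor of the pair. The gap to compound 1, at 400 nM, lies beyond the usual scatter of repeated measurements. These two compounds differ in more than one place, so their gap cannot be tied to any single change.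

The next compound to be tested is compound 3 `COc1cc(-c2ncn(C)c2-c2ccc(N(C)C)cc2)cc(Br)c1OC`. It differs from compound 2 by one small swap: bromo in place of chloro on an aromatic carbon. In words, bromo takes the place of chloro on an aromatic carbon, ortho to a methoxy group.

Going by the values given here, no measured pair shows this swap, so there is no direct precedent for its effect in this assay. With the rest of the structure unchanged, compound 2 at 2300 nM is the natural starting point, and no change beyond the scatter is expected. The estimated step is a 1.2-fold lower number from compound 2 to compound 3 (0.06 log units; within the scatter). For compound 3 the expected value is 2000 nM, with a range of 750 nM to 5500 nM.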

Compound 3, half-maximal inhibitory concentration: 860 nM
The estimate for compound 3 lay 2.3-fold (0.37 log units) above the measured number; the range from low to high includes it.
By their numbers in this assay, from the lowest: compound 1; then compound 3; then compound 2.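

This is the only pair shown that differs in one place, so it isolates the halogen on this aromatic carbon, ortho to a methoxy group. In this assay, bromo in place of chloro gives a 2.7-fold lower number from compound 2 to compound 3 (0.43 log units; beyond the scatter), a modest step but one beyond the scatter, so even this one-atom swap, with no ring, hydrogen-bond donor, hydrogen-bond acceptor or net charge entering or leaving, moves the number at this position. Nothing available accounts for the lower number with bromo, so the result stands as an observation without an explanation.

One pair sets no trend: whether the same swap would move the number by a similar amount on the core of compound 1 remains an open question. Also open, going by these compounds, is how this same carbon would read with an iodo group, a methyl group, a nitrile or a plain hydrogen, and so whether the gain stops at bromo or continues along such a series.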